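Methylsulfonyl in place of sec-butoxycarbonyl: working notes

This account rests on a few compounds, and the source may have more. Where it says the series, first, only, none or still open, it means among the compounds named here.

Measured in a functional assay on MCF7 cells (Homo sapiens) for antiproliferative activity; a lower number here means a stronger inhibitor, a higher number a weaker inhibitor:
- compound 1 `COc1ccc(C(=O)Nc2ccc(O)c3c(=O)cc(-c4ccccc4Cl)oc23)cc1`: 3500 nM
- compound 2 `CCC(C)OC(=O)Nc1ccc(O)c2c(=O)cc(-c3ccccc3Cl)oc12`: 30000 nM

Compound 2 holds the higher of the two numbers, so it is the weaker inhibitor of the pair. Compound 3 `CS(=O)(=O)Nc1ccc(O)c2c(=O)cc(-c3ccccc3Cl)oc12` has not yet been measured. It carries methylsulfonyl in place of sec-butoxycarbonyl on a nitrogen on an aromatic ring. Cut one bond further out, the change reads (sec-butoxycarbonyl)amino to methanesulfonamido.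

Going by the values given here, only one measured step bears on this change: an 8.6-fold higher number from compound 1 to compound 2 (0.93 log units; beyond the scatter). That modest step, beyond the scatter, put sec-butoxy in place of 4-methoxyphenyl on a carbonyl carbon. Among the compounds with values here, no measured compound carries a sulfonyl group, so the step offers a guide to size but no direct evidence of direction. With compound 2 at 30000 nM, the higher end of the two numbers, a modest move to a lower number is tentatively expected in this assay. The expected step is a 2.5-fold lower number from compound 2 to compound 3 (0.40 log units; beyond the scatter). The estimate for compound 3 is 12000 nM, with an expected range of 3000 nM to 40000 nM.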

Compound 3, half-maximal inhibitory concentration: 25000 nM
For compound 3 the middle estimate is 2.1-fold (0.32 log units) below the measured one; low and high end bracket the measured number.
By their numbers in this assay, from the lowest: compound 1; then compounds 3 and 2 (each within the scatter of the next).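

In this assay, methylsulfonyl in place of sec-butoxycarbonyl on a nitrogen on an aromatic ring gives a 1.2-fold lower number from compound 2 to compound 3 (0.08 log units; within the scatter), so a sulfonyl group and a carbamate-type carbonyl cannot be told apart at this position, even though 7 heavy atoms leave and 4 enter. The other comparison gives a 7.1-fold higher number from compound 1 to compound 3 (0.85 log units; beyond the scatter), which sits alongside an 8.6-fold higher number from compound 1 to compound 2 (0.93 log units; beyond the scatter): compound 1 now stands apart from two different substituents, and among these three compounds it is the strongest inhibitor. Of the three groups on this nitrogen, only the (4-methoxyphenyl)carbonyl of compound 1 carries a ring, but with three compounds this is an observation and not a rule, and nothing available accounts for the difference.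

On these data alone, it remains open whether the advantage of compound 1 follows the aromatic ring or needs the carbonyl that joins it to the nitrogen, and a 4-methoxyphenylsulfonyl group on the same nitrogen would separate the two. The compounds shown also leave open how the free amine or a plain acetyl group on this nitrogen would read in this assay.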